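Compound 3 to compound 4: hydroxymethyl removed

The source may report more compounds than this note shows. Statements on the series, on what has been measured and on what is new or still open speak of the compounds shown alone.

In a physicochemical assay for lipophilicity, measured as octanol-water partition, at pH 7.4 (a lower number here means a more polar compound, a higher number a more lipophilic compound), compound 1 (`CC(C)c1noc(N2CCC(Oc3cc(N4CCc5cc(N6CCCS6(=O)=O)ccc54)ncn3)CC2)n1`) stands at 3.2 and compound 2 (`CC(C)c1noc(N2CCC(Oc3cc(N4CCc5cc([S+]([O-])CCO)ccc54)ncn3)CC2)n1`) at 2.7 while compound 3 (`CC(C)c1noc(N2CCC(Oc3cc(N4CCc5cc(S(=O)(=O)CCO)ccc54)ncn3)CC2)n1`) stands at 2.7 and so is level with compound 2, the two together lowest of the three. Compound 4 (`CC(C)c1noc(N2CCC(Oc3cc(N4CCc5cc(S(C)(=O)=O)ccc54)ncn3)CC2)n1`) has hydrogen in place of hydroxymethyl on a saturated chain carbon bound to a sulfonyl sulfur. Within the data shown here, no measured step makes this change directly. The indirect guides are a number 0.50 log units lower from compound 1 to compound 3 (beyond the scatter) and a number 0.50 log units lower from compound 1 to compound 2 (beyond the scatter) along with no change at the digits printed from compound 2 to compound 3 (within the scatter) for the sulfur group. A small rise in this assay is expected, with a number 0.20 log units higher from compound 3 to compound 4 (within the scatter) as the estimated step. Compound 4 is expected at 2.9 (range 2.5 to 3.3).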

Compound 4, distribution coefficient: 3.1
Estimate against measurement, compound 4: 0.20 log units below; the measured number falls inside the stated range.
By their numbers in this assay, from the lowest: compounds 2 and 3 (each within the scatter of the next); then compounds 4 and 1 (each within the scatter of the next).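

In this assay, among these compounds, the step of a number 0.40 log units higher from compound 3 to compound 4 (beyond the scatter) gives the first direct reading of hydroxymethyl leaving a saturated chain carbon bound to a sulfonyl sulfur. On the aromatic carbon, methylsulfonyl also separates from the group of compound 2 with a number 0.40 log units higher from compound 2 to compound 4 (beyond the scatter) and yet shows a number 0.10 log units lower from compound 1 to compound 4 (within the scatter) against the ring-bearing group, so an open-chain sulfonyl and the ring group are not told apart in this read-out. From the compounds shown here alone, whether a longer chain, an amine or a carboxylic acid at this carbon would follow the same step remains open. No measurement shown gives a reason for these steps.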